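A Nitrophenyl Variant of Compound 3

The compounds below may be only part of what the source reports. "The series", "measured", "known", "first", "only" and "open" are said of these compounds alone.

Three compounds have numbers in a functional assay on cells (Cancer cell lines, Homo sapiens) for inhibition, read by MTT assay, with a stated time of 48 h; a higher number here means a weaker inhibitor, a lower number a stronger inhibitor:

Compound 1, `Cc1ccc(/C=C/C(=O)NNC(=O)c2ccc3c(c2)OCCO3)cc1`, gives 1050 nM.
Compound 2, `O=C(/C=C/c1ccc(F)cc1)NNC(=O)c1ccc2c(c1)OCCO2`, gives 990 nM.
Compound 3, `O=C(/C=C/c1ccccc1Br)NNC(=O)c1ccc2c(c1)OCCO2`, gives 2110 nM.

Compound 3 carries the highest of the three numbers. The nearer of the two steps leading to it is a 2.0-fold higher number from compound 1 to compound 3 (0.30 log units; within the scatter), which stays within the scatter; the further one is a 2.1-fold higher number from compound 2 to compound 3 (0.33 log units; beyond the scatter), which just passes beyond it. The two lower compounds sit close together, the shift between them being a 1.1-fold lower number from compound 1 to compound 2 (0.03 log units; within the scatter).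

Compound 4, `O=C(/C=C/c1cccc([N+](=O)[O-])c1)NNC(=O)c1ccc2c(c1)OCCO2`, has not yet been measured. It differs from compound 3 in a single place: 3-nitrophenyl in place of 2-bromophenyl on a double-bonded chain carbon bound to a double-bonded chain carbon. The measured steps that bear on this are the two aryl exchanges at the same place, a 2.0-fold higher number from compound 1 to compound 3 (0.30 log units; within the scatter) and a 2.1-fold higher number from compound 2 to compound 3 (0.33 log units; beyond the scatter), both modest. Neither involves a nitro group, so the direction can only be guessed from compound 3 holding the highest number while the other two aryl groups sit lower. A modest move back toward compound 1 and compound 2 is expected, with a step of a 1.5-fold lower number from compound 3 to compound 4 (0.18 log units; within the scatter). Compound 4 is accordingly estimated at 1400 nM, in a range from 600 nM to 3500 nM.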

Compound 4, half-maximal inhibitory concentration: 1560 nM
Compound 4: middle estimate off by 1.1-fold (0.05 log units), on the low side; the range from low to high includes it.
By their numbers in this assay, from the lowest: compounds 2, 1, 4 and 3 (each within the scatter of the next, the first and the last beyond it).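

In this assay the exchange of 2-bromophenyl for 3-nitrophenyl, on a double-bonded chain carbon bound to a double-bonded chain carbon, brings in nitrogen and oxygen, more heavy atoms and hydrogen-bond acceptors, yet the step (a 1.4-fold lower number from compound 3 to compound 4 (0.13 log units; within the scatter)) stays within the scatter. For the compounds shown here, the new compound is also within the scatter of the other two aryl compounds (a 1.6-fold higher number from compound 2 to compound 4 (0.20 log units; within the scatter); a 1.5-fold higher number from compound 1 to compound 4 (0.17 log units; within the scatter)), so it falls clearly with neither end of the one gap that passed beyond the scatter among the earlier compounds, the gap between compound 2 and compound 3, and this place on the chain therefore accepts a nitro-bearing phenyl group with no step beyond the scatter from any of the three others. No measurement is available that would explain these numbers.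

Because the 3-nitrophenyl and 2-bromophenyl names differ in both the substituent and its numbered ring position, the compounds shown cannot separate the contribution of the nitro group from that of its location. They also leave open what an amine or a carboxylic acid on the phenyl ring would do in this assay, and whether a longer chain could replace the aryl group at this place.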